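A Thiazole in Place of a Pyrazole: What to Expect

This account rests on a few compounds, and the source may have more. Where it says the series, first, only, none or still open, it means among the compounds named here.

Compound 1, `CCCCOC(=O)NS(=O)(=O)c1sc(CC(C)C)cc1-c1ccc(CN2C(=O)CCC2=O)cc1`, gives in an assay on membranes from uterus for displacement of a labelled ligand from Angiotensin type II receptor (Sus scrofa), with a stated time of 1.5 h (a higher number here means a weaker inhibitor, a lower number a stronger inhibitor), only a limit of the assay, > 10000 nM.
Compound 2, `CCCCOC(=O)NS(=O)(=O)c1sc(CC(C)C)cc1-c1ccc(CN2CCN(C)C2=O)cc1`, gives in this assay 16.5 nM.
Compound 3, `CCCCOC(=O)NS(=O)(=O)c1sc(CC(C)C)cc1-c1ccc(Cn2ccc(C(F)(F)F)n2)cc1`, gives in this assay 9.5 nM.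

Compound 3 holds the lowest of the two numbers shown, yet compound 2 stands within the scatter of it: a 1.7-fold lower number from compound 2 to compound 3 (0.24 log units; within the scatter). All three share one core and differ only in the group on a saturated chain carbon bound to an aromatic carbon. The steps of an at least 600-fold lower number from compound 1 to compound 2 (2.78 log units; beyond the scatter) and an at least 1000-fold lower number from compound 1 to compound 3 (3.02 log units; beyond the scatter) show that this position accepts either an oxoimidazolidinyl or a trifluoromethyl-pyrazolyl group, while the dioxopyrrolidinyl of compound 1 sits at the limit of > 10000 nM in this assay, at which 1 of the 3 values shown sits.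

Compound 4, `CCCCOC(=O)NS(=O)(=O)c1sc(CC(C)C)cc1-c1ccc(Cc2nccs2)cc1`, is not yet measured. 1,3-thiazol-2-yl in place of 3-(trifluoromethyl)-1H-pyrazol-1-yl on a saturated chain carbon bound to an aromatic carbon The step from compound 2 to compound 3, a swap between two different five-membered rings, stayed within the scatter, and the incoming group is again one five-membered aromatic ring with 2 hetero atoms. The change from compound 3 to compound 4 is therefore expected to give a step of a 2.1-fold higher number from compound 3 to compound 4 (0.32 log units; beyond the scatter) in this assay, no larger than the scatter. Compound 4 is estimated at 20 nM, between 6 nM and 70 nM.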

Compound 4, inhibition constant: 3.2 nM
Estimate against measurement, compound 4: 6.3-fold (0.80 log units) above; the whole stated range lies above it.
By their numbers in this assay, from the lowest: compound 4; then compounds 3 and 2 (each within the scatter of the next). At a limit, above all of these: compound 1.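

Compounds 2 and 3 could not be told apart in this assay, but compound 4 separates from both of them (a 3.0-fold lower number from compound 3 to compound 4 (0.47 log units; beyond the scatter); a 5.2-fold lower number from compound 2 to compound 4 (0.71 log units; beyond the scatter)), so groups that all keep a low number on a saturated chain carbon bound to an aromatic carbon can still differ beyond the scatter. The trifluoromethyl group is also shown not to be needed for a low number here, as the 1,3-thiazol-2-yl has 5 heavy atoms against 9 for the 3-(trifluoromethyl)-1H-pyrazol-1-yl it replaces and still gives the lowest number of the series. The gap to the dioxopyrrolidinyl compound remains open-ended (an at least 3100-fold lower number from compound 1 to compound 4 (3.49 log units; beyond the scatter)), as compound 1 is only a limit of the assay: the limit of > 10000 nM in this assay, at which 1 of the 4 values shown sits.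

The step from compound 3 to compound 4 changes the ring and removes the trifluoromethyl group together, so the shown compounds cannot say which of the two changes accounts for the lower number. A 1H-pyrazol-1-yl without trifluoromethyl, or a 1,3-thiazol-2-yl carrying a trifluoromethyl or a methyl group, would separate those two changes, and no such compound is among those shown.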